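This account rests on a few compounds, and the source may have more. Where it says the series, first, only, none or still open, it means among the compounds named here.

Of the compounds shown here, three have been measured in an assay (Rattus norvegicus) for inhibition of Fatty-acid amide hydrolase 1 (Homo sapiens); a higher number here means a weaker inhibitor, a lower number a stronger inhibitor. Compound 1 `COC(=O)c1cccc(-c2cnc(C(=O)CCCCCCc3ccccc3)o2)c1` gives 12 nM, compound 2 `NS(=O)(=O)c1ccc(-c2cnc(C(=O)CCCCCCc3ccccc3)o2)cc1` gives 10 nM, and compound 3 `Cc1cccc(-c2cnc(C(=O)CCCCCCc3ccccc3)o2)n1` gives 3.3 nM. Compound 3 stands at the lowest of the three numbers in this assay; compound 2 lies nearest to it and compound 1 furthest, and both of these gaps lie beyond the scatter, so compound 3 is the strongest inhibitor measured so far.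

Compound 4 `CSc1cnc(C(=O)CCCCCCc2ccccc2)o1` has not yet been measured in this assay. Relative to compound 3 the change is methylsulfanyl in place of 6-methylpyridin-2-yl on an aromatic carbon. Among the measured compounds shown here, no two measured compounds differ in one place, so no measured step of comparable kind is at hand to set the size of this one. All three measured compounds carry a large group at this place; nothing measured shows how a two-atom group behaves there. The loss of the six-membered aromatic ring is a large change in the count of heavy atoms, and the working expectation is a step towards a higher number in this assay, clearly beyond the scatter, though not a collapse of inhibition.

For compound 4 the expected value in this assay is 60 nM, with an estimated range of 15 nM to 250 nM. The expected step is an 18-fold higher number from compound 3 to compound 4 (1.26 log units; beyond the scatter).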

Compound 4, inhibition constant: 25 nM
The estimate for compound 4 lay 2.4-fold (0.38 log units) above the measured number; the measured number falls inside the stated range.
By their numbers in this assay, from the lowest: compound 3; then compounds 2 and 1 (each within the scatter of the next); then compound 4.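

The step of a 7.6-fold higher number from compound 3 to compound 4 (0.88 log units; beyond the scatter) in this assay is the only one read so far at this place, the aromatic carbon next to the ring oxygen, and it is beyond the scatter. It shows that this place does not need a six-membered aromatic ring for inhibition to persist: with methylsulfanyl there, compound 4 still gives 25 nM, although the group has 2 heavy atoms where 6-methylpyridin-2-yl has 7. Nothing at hand accounts for the size of this step.

With one step, the effects of removing the ring, reducing the heavy-atom count and introducing sulfur cannot be separated, and the methyl on the pyridine ring cannot be assessed on its own. An unsubstituted pyridin-2-yl, a phenyl, a plain methyl or a hydrogen at this place would help separate these contributions, while a methylsulfonyl group would test whether the sulfur-linked group tolerates added oxygen atoms.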